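Swapping the hydroxyethyl amide for a methyl ester

The compounds below may be only part of what the source reports. "The series", "measured", "known", "first", "only" and "open" are said of these compounds alone.

Three compounds have been measured in an ADME assay on BaF3 cells (Mus musculus) for cytotoxicity; a higher number here means that more compound is needed for the effect, a lower number that less compound is needed:
Compound 1 `CN1CCN(C(=O)c2cc3c(Nc4ccc(OC(F)(F)F)cc4)ncnc3s2)CC1` gives 2690 nM.
Compound 2 `CCNC(=O)c1cc2c(Nc3ccc(OC(F)(F)F)cc3)ncnc2s1` reaches only the assay limit of > 10000 nM.
Compound 3 `O=C(NCCO)c1cc2c(Nc3ccc(OC(F)(F)F)cc3)ncnc2s1` likewise reaches only the assay limit of > 10000 nM.

Compound 3 thus stands at the upper edge of what this assay reports, a position it shares with compound 2 (the limit of > 10000 nM in this assay, at which 2 of the 3 values shown sit). The next compound, compound 4 `COC(=O)c1cc2c(Nc3ccc(OC(F)(F)F)cc3)ncnc2s1`, differs from it in one place: methoxy in place of (2-hydroxyethyl)amino on a carbonyl carbon. Among the measured compounds shown here, the measured steps so far are an at least 3.7-fold higher number from compound 1 to compound 2 (0.57 log units; beyond the scatter), an at least 3.7-fold higher number from compound 1 to compound 3 (0.57 log units; beyond the scatter), and a step that the two limits leave unreadable from compound 2 to compound 3. None of them exchanges an amide for an ester, so they give only indirect guidance. Both amides without the basic ring sat at the limit, and compound 4 is expected to stay there too, with a step that the limit leaves unreadable from compound 3 to compound 4. The estimate for compound 4 is 12000 nM, within 3000 nM to 40000 nM.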

Compound 4, half-maximal effective concentration: > 10000 nM
Compound 4 ended at the assay's limit (the forecaster's own chance of this, stated with the estimate: 65%); the middle value is on the limit's open side.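

In this assay compound 4 gives > 10000 nM as a limit of the assay, not a number. Methoxy on the carbonyl carbon, with no nitrogen in the group there, still differs from 4-methylpiperazin-1-yl, with an at least 3.7-fold higher number from compound 1 to compound 4 (0.57 log units; beyond the scatter) on that change. The steps among compound 2, compound 3 and compound 4 cannot be read, so the ester and the two amides cannot be ordered, and all three share one edge: the limit of > 10000 nM in this assay, at which 3 of the 4 values shown sit.

Still open, on these data alone, is how far past the limit these three lie, and whether a carboxylic acid or a 2-aminoethylamino group on the carbonyl carbon would give a readable number.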